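The source may hold more compounds than are shown below. What is called first, only, known or untested is meant among the compounds shown, and "the series" means these compounds.

Among the compounds with values here, compound 2 `Cc1ccccc1NC(=O)CCC(=O)OCCCCCCSc1ccc([N+](=O)[O-])c2nonc12` stands lowest of the two numbers measured so far: in a functional assay on HOS cells (Homo sapiens) for inhibition, read by MTT assay, with a stated time of 72 h (a higher number here means a weaker inhibitor, a lower number a stronger inhibitor), compound 2 gives 4020 nM, while compound 1 `O=C(O)CCC(=O)OCCCCCCSc1ccc([N+](=O)[O-])c2nonc12` gives 8740 nM, and the step of a 2.2-fold lower number from compound 1 to compound 2 (0.34 log units; beyond the scatter) is modest though beyond the scatter. Compound 3 `COc1ccccc1NC(=O)CCC(=O)OCCCCCCSc1ccc([N+](=O)[O-])c2nonc12` differs from compound 2 by methoxy in place of methyl on an aromatic carbon. Within the data shown here, no measured step bears on this change; the only step known concerns (2-methylphenyl)amino in place of hydroxy, not the ring substituent, so no step beyond the scatter is expected, a 1.0-fold lower number from compound 2 to compound 3 (0.00 log units; within the scatter). Compound 3 is therefore estimated at 4000 nM, within 1500 nM to 11000 nM.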

Compound 3, half-maximal inhibitory concentration: 2850 nM
For compound 3 the middle estimate is 1.4-fold (0.15 log units) above the measured one; the range from low to high includes it.
By their numbers in this assay, from the lowest: compounds 3 and 2 (each within the scatter of the next); then compound 1.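

In this assay methoxy in place of methyl on this aromatic carbon, ortho to a large group, gives a 1.4-fold lower number from compound 2 to compound 3 (0.15 log units; within the scatter) and so leaves the number indistinguishable from that of the methyl compound. With either group at this place the aryl amide stays beyond the scatter of the acid, as (2-methoxyphenyl)amino in place of hydroxy gives a 3.1-fold lower number from compound 1 to compound 3 (0.49 log units; beyond the scatter) and thus a step of modest size. No evidence on the cause of either step is available. Open, as far as these compounds go, is how an unsubstituted phenyl ring, a chlorine or an amine at this place would compare, and whether a shorter or longer chain would shift these numbers.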